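Shortening the butoxy chain: compound 2 to compound 3

The source may hold more compounds than are shown below. What is called first, only, known or untested is meant among the compounds shown, and "the series" means these compounds.

Measured compounds:
- compound 1, `CN(C)CCNc1ccnc2cc(OCc3ccc(F)cc3)ccc12`, 370 nM
- compound 2, `CCCCOc1ccc2c(Cl)ccnc2c1`, 2740 nM

In a functional assay on HCT-116 cells (Homo sapiens) for cytotoxicity, read by MTT assay, with a stated time of 48 h (a lower number here means a stronger inhibitor, a higher number a weaker inhibitor), compound 2 gives 2740 nM, the highest of the two numbers recorded so far. Its nearest neighbour, compound 1, gives 370 nM in this assay, a lower number that lies beyond the scatter; the two structures differ in several places at once, so only the two values themselves can be compared. Compound 3, `CCOc1ccc2c(Cl)ccnc2c1`, has not yet been tested in this assay. It differs from compound 2 by hydrogen in place of ethyl on a saturated chain carbon, two bonds along the chain from an oxygen on an aromatic ring, that is, butoxy to ethoxy on the shared core. Within the data shown here, no measured pair shows this kind of change here, so the direction rests on expectation alone. A small step is expected from compound 2 to compound 3, a 1.3-fold higher number from compound 2 to compound 3 (0.11 log units; within the scatter), not clearly beyond the scatter and, if anything, toward a weaker inhibitor. Compound 3 is therefore estimated at 3500 nM in this assay, with a range from 1200 nM to 10000 nM.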

Compound 3, half-maximal inhibitory concentration: 3160 nM
Compound 3: middle estimate off by 1.1-fold (0.04 log units), on the high side; measured number inside the range.
By their numbers in this assay, from the lowest: compound 1; then compounds 2 and 3 (each within the scatter of the next).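

Among these compounds, compound 2 and compound 3 form the only pair here that differs in one place, so they give the first direct reading of this position. In this assay, hydrogen in place of ethyl on a saturated chain carbon, two bonds along the chain from an oxygen on an aromatic ring, gives a 1.2-fold higher number from compound 2 to compound 3 (0.06 log units; within the scatter), which shows that on the shared core, butoxy and ethoxy cannot be told apart in this assay. No measurement shown accounts for this result.

From the compounds shown here alone, it remains open whether a methoxy group, a longer chain such as hexyloxy, or a chain ending in an amine would also stay within the scatter at this oxygen. Compound 1 differs from both of these compounds in several places, so no single group can be credited with its value of 370 nM.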